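A few compounds are considered here, and "the series" means these few. Any claim that something is new, unique, unknown or untested is made for them only; others in the source may bear on it.

Working notes on the shared core, read in an assay on CHO-K1 cells for displacement of a labelled ligand from prostaglandin E2 receptor EP1 subtype (Homo sapiens); a lower number here means a stronger inhibitor, a higher number a weaker inhibitor. Compound 1 `Cc1cc(C(=O)O)nn1Cc1cc(Br)ccc1OCc1ccc(F)cc1` gives 7.41 nM; compound 2 `Cc1cc(C(=O)O)nn1Cc1cc(Br)ccc1OCc1c(F)cccc1F` gives 14.8 nM; compound 3 `Cc1cc(C(=O)O)nn1Cc1cc(Br)ccc1OCc1cccc(Cl)c1` gives 115 nM, the highest of the three numbers and thus the weakest point of the set. The steps of a 2.0-fold higher number from compound 1 to compound 2 (0.30 log units; within the scatter), a 16-fold higher number from compound 1 to compound 3 (1.19 log units; beyond the scatter) and a 7.8-fold higher number from compound 2 to compound 3 (0.89 log units; beyond the scatter) each swap the whole benzyl substitution pattern at once. Compound 4 `Cc1cccc(COc2ccc(Br)cc2Cn2nc(C(=O)O)cc2C)c1` differs from compound 3 by methyl in place of chloro on an aromatic carbon. Within the data shown here, none of the measured steps exchanges one group for another at a fixed position on that ring, so they frame compound 3 as the weak end but set no direction for this exchange. No step beyond the scatter is expected here: a 1.2-fold lower number from compound 3 to compound 4 (0.06 log units; within the scatter). Compound 4 is estimated at 100 nM, with a range from 35 nM to 300 nM.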

Compound 4, half-maximal inhibitory concentration: 126 nM
The estimate for compound 4 lay 1.3-fold (0.10 log units) below the measured number; low and high end bracket the measured number.
By their numbers in this assay, from the lowest: compounds 1 and 2 (each within the scatter of the next); then compounds 3 and 4 (each within the scatter of the next).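

In this assay, among these compounds, the exchange of chloro for methyl gives a 1.1-fold higher number from compound 3 to compound 4 (0.04 log units; within the scatter) and is the first exchange at a fixed position on this ring, with no change beyond the scatter. Compound 4 also keeps the large gap seen with chloro, with an 8.5-fold higher number from compound 2 to compound 4 (0.93 log units; beyond the scatter) and a 17-fold higher number from compound 1 to compound 4 (1.23 log units; beyond the scatter), so that gap does not depend on chloro alone. Nothing at hand explains why these two groups read alike. Open, going by these compounds, is whether a methoxy group or an amine on the same aromatic carbon would read like chloro and methyl. Also open, on these data alone, is how methyl or chloro would read in place of the fluoro of compound 1.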